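Methyl for Fluoro on the Triazole Aryl Ring

The source may hold more compounds than are shown below. What is called first, only, known or untested is meant among the compounds shown, and "the series" means these compounds.

Compound 1 `C=C1C[C@]23C[C@@]1(O)CC[C@H]2c1ccc(O)c(C)c1[C@@H]3Cn1cc(-c2ccc(OC)cc2)nn1` gives > 20000 nM in a functional assay on A549 cells (Homo sapiens) for cytotoxicity, read by MTT assay, with a stated time of 4 days (a higher number here means a weaker inhibitor, a lower number a stronger inhibitor), a limit of the assay rather than a number.
Compound 2 `Cc1c(O)ccc2c1[C@H](Cn1cc(-c3ccc(F)cc3)nn1)[C@@]13CC(=O)[C@@](C)(CC[C@@H]21)C3` gives > 20000 nM in this assay, also a limit.

For the measured compounds named here, compound 2 stands at the limit of > 20000 nM in this assay, at which 2 of the 2 values shown sit, so no number is known for it, and the one further value shown is a limit as well. Compound 3 `Cc1ccc(-c2cn(C[C@H]3c4c(ccc(O)c4C)[C@@H]4CC[C@@]5(C)C[C@]43CC5=O)nn2)cc1` differs from compound 2 in a single place: methyl in place of fluoro on an aromatic carbon. Going by the values given here, no step between measured compounds is available to calibrate such a change, and both measured values are limits. The step from compound 2 to compound 3 in this assay is therefore expected to be none beyond the scatter, with the estimate set as a step that the limit leaves unreadable from compound 2 to compound 3. Compound 3 is expected to give about 25000 nM, within a range from 10000 nM to 60000 nM, and most probably the assay will again report only a limit for compound 3.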

Compound 3, half-maximal inhibitory concentration: > 20000 nM
Compound 3 ended at the assay's limit; the forecaster's own chance of this, stated with the estimate: 80%; the middle value lies beyond the limit too.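

In this assay compound 3 gives > 20000 nM, a limit of the assay and not a number. Compound 2 also stands at a limit, so no step can be read between compound 2 and compound 3. The compounds shown leave open how 4-fluorophenyl and 4-methylphenyl compare, as every value is a limit: the limit of > 20000 nM in this assay, at which 3 of the 3 values shown sit.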